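Naphthalen-2-yl in place of phenyl: working notes

This account rests on a few compounds, and the source may have more. Where it says the series, first, only, none or still open, it means among the compounds named here.

Growth inhibition across the series is read in a functional assay on cells (Cancer cell lines, Homo sapiens) for cytotoxicity, read by sulforhodamine B assay, with a stated time of 48 h; a higher number here means a weaker inhibitor of growth, a lower number a stronger inhibitor of growth.

compound 1 `O=C1N=C(N2N=C(c3ccccc3)CC2c2ccccc2O)S/C1=C1/C(=O)Nc2ccccc21`: 4770 nM
compound 2 `COc1ccc(C2CC(c3ccccc3)=NN2C2=NC(=O)/C(=C3\C(=O)Nc4ccccc43)S2)cc1`: 4580 nM
compound 3 `COc1ccc(C2CC(c3ccccc3)=NN2C2=NC(=O)/C(=C3\C(=O)Nc4ccc(Br)cc43)S2)cc1`: 480 nM

Compound 2 stands second highest of the three numbers. a 1.0-fold lower number from compound 1 to compound 2 (0.02 log units; within the scatter) lies within the scatter, so no order is drawn between these two. Among the compounds with values here, the only step that clears the scatter is a 9.5-fold lower number from compound 2 to compound 3 (0.98 log units; beyond the scatter), a modest gain from bromo in place of hydrogen on an aromatic carbon.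

Compound 4 `COc1ccc(C2CC(c3ccc4ccccc4c3)=NN2C2=NC(=O)/C(=C3\C(=O)Nc4ccccc43)S2)cc1` differs from compound 2 in one place: naphthalen-2-yl in place of phenyl on a carbon with a double bond to nitrogen. Neither measured step touches this position: the step from compound 1 to compound 2 concerns the saturated ring carbon, the step from compound 2 to compound 3 an aromatic carbon. Within the data shown here, no measured step therefore bears on the change, and the data give no direction for it. For compound 4 the expected step in this assay is a 1.1-fold lower number from compound 2 to compound 4 (0.06 log units; within the scatter), none beyond the scatter. Compound 4 is estimated at 4000 nM, with a range from 1500 nM to 12000 nM.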

Compound 4, concentration for total growth inhibition: 32800 nM
Compound 4: middle estimate off by 8.2-fold (0.91 log units), on the low side; measured number above the stated range.
By their numbers in this assay, from the lowest: compound 3; then compounds 2 and 1 (each within the scatter of the next); then compound 4.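

In this assay, the position on the carbon with a double bond to nitrogen proves sensitive to its substituent: naphthalen-2-yl in place of phenyl gives a 7.2-fold higher number from compound 2 to compound 4 (0.86 log units; beyond the scatter). This is a loss of growth inhibition, opposite in direction to the gain from bromo at a different place in a 9.5-fold lower number from compound 2 to compound 3 (0.98 log units; beyond the scatter), so the phenyl here cannot be swapped for a second fused aromatic ring without cost. Nothing available explains this loss.

From the compounds shown here alone, with one replacement at this position, it remains open whether the loss reflects the added ring itself or is specific to naphthalen-2-yl. Also open, going by these compounds, are how a methyl group or a phenyl carrying an amine would read at this carbon, and whether bromo on the aromatic carbon would give a similar gain alongside naphthalen-2-yl.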